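Swapping the Aryl Group on the Carbonyl of Compound 1

The source may hold more compounds than are shown below. What is called first, only, known or untested is meant among the compounds shown, and "the series" means these compounds.

Measured compounds:
Compound 1 `O=C(/C=C/c1ccc2c(c1)B(O)OC2)c1ccc(F)cc1` — in a toxicity assay on MCF-10A cells (Homo sapiens) for cytotoxicity, read by MTT assay, with a stated time of 48 h (on this read-out lower numbers stand for stronger inhibition and higher numbers for weaker inhibition), compound 1 gives 11800 nM
Compound 2 `CCc1ccc(C(=O)/C=C/c2ccc3c(c2)B(O)OC3)cc1` — in this assay compound 2 gives 8800 nM

Compound 1 gives the higher of the two numbers, though the gap to compound 2 lies within the scatter. Among the measured compounds shown here, the single measured step, a 1.3-fold lower number from compound 1 to compound 2 (0.13 log units; within the scatter), is ethyl in place of fluoro on an aromatic carbon. Compound 3 `O=C(/C=C/c1ccc2c(c1)B(O)OC2)c1cccc(O)c1` is still to be measured; it differs from compound 1 by 3-hydroxyphenyl in place of 4-fluorophenyl on a carbonyl carbon. For the measured compounds named here, no measured step covers a hydroxyl entering, and the one change made at the same place stayed within the scatter, so no step beyond the scatter is expected. Compound 3 is expected at 12000 nM, within 5000 nM to 30000 nM. The expected step, a 1.0-fold higher number from compound 1 to compound 3 (0.01 log units; within the scatter), lies within the scatter.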

Compound 3, half-maximal inhibitory concentration: 25300 nM
Estimate against measurement, compound 3: 2.1-fold (0.32 log units) below; low and high end bracket the measured number.
By their numbers in this assay, from the lowest: compounds 2 and 1 (each within the scatter of the next); then compound 3.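

In this assay, among the compounds shown here, 3-hydroxyphenyl in place of 4-fluorophenyl on the carbonyl carbon gives a 2.1-fold higher number from compound 1 to compound 3 (0.33 log units; beyond the scatter) and is thus the first step at this place to pass the scatter, though only modestly. The aryl group here can therefore shift the number upward, whereas ethyl in place of fluoro did not move it beyond the scatter. Nothing at hand explains this step.

The compounds shown leave open whether the shift belongs to the hydroxyl itself or to its placement in 3-hydroxyphenyl. They also leave open how an amine or a carboxylic acid on this aryl ring would read.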